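A few compounds are considered here, and "the series" means these few. Any claim that something is new, unique, unknown or untested is made for them only; others in the source may bear on it.

Measured so far in a functional assay on PC-3 cells (Homo sapiens) for cytotoxicity, read by MTT assay, with a stated time of 48 h; a lower number here means a stronger inhibitor, a higher number a weaker inhibitor:
Compound 1 `CC1=NN(S(=O)(=O)c2ccc([N+](=O)[O-])cc2)C(c2cc(Cl)ccc2O)C1` gives 44200 nM.
Compound 2 `CC1=NN(C(=O)CN2CCCCC2)C(c2ccccc2O)C1` gives 5890 nM.
Compound 3 `O=C(CNC1CC1)N1N=C(c2cc3ccccc3oc2=O)CC1c1ccccc1` gives 28500 nM.

Among these three numbers compound 3 holds the second highest. Its nearest neighbour is compound 1, and that gap lies within the scatter of repeated measurements, so the two cannot be placed in any order. Compound 2, built on a different core with a different group on the chain, stands furthest from compound 3, and that gap does lie beyond the scatter.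

Compound 4 `NC(=O)C1CCN(CC(=O)N2N=C(c3cc4ccccc4oc3=O)CC2c2ccccc2)CC1` differs from compound 3 in one place: 4-carbamoylpiperidin-1-yl in place of cyclopropylamino on a saturated chain carbon bound to a carbonyl carbon. For the measured compounds named here, no pair of measured compounds carries this change on the same core, so no measured step tells its size. For compound 4 the expectation is a step of modest size from compound 3, estimated as a 1.6-fold lower number from compound 3 to compound 4 (0.20 log units; within the scatter), more likely toward a lower number than a higher one, though not clearly beyond the scatter. In this assay compound 4 is expected to give 18000 nM, within a range from 6000 nM to 55000 nM.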

Compound 4, half-maximal inhibitory concentration: 8310 nM
The estimate for compound 4 lay 2.2-fold (0.34 log units) above the measured number; the measured number falls inside the stated range.
By their numbers in this assay, from the lowest: compounds 2 and 4 (each within the scatter of the next); then compounds 3 and 1 (each within the scatter of the next).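

On the saturated chain carbon bound to a carbonyl carbon, the shared core accepts a larger group without loss: in this assay, 4-carbamoylpiperidin-1-yl in place of cyclopropylamino gives a 3.4-fold lower number from compound 3 to compound 4 (0.54 log units; beyond the scatter), a step beyond the scatter. For the compounds shown here, this is the first measured step at this position, and it shows that the group carried on this chain carbon can change the number on an otherwise unchanged core. No measured evidence accounts for the size or direction of this step.

The compounds shown leave open whether the step belongs to the six-membered ring or to its carbamoyl group, a question that a plain piperidin-1-yl on the same core could separate. Also open, on these data alone, is how a carboxylic acid in place of the carbamoyl group, or a longer chain carrying the same ring, would read in this assay.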